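Trifluoromethyl on the Outer Ring of Compound 1

The compounds below may be only part of what the source reports. "The series", "measured", "known", "first", "only" and "open" are said of these compounds alone.

Compound 1 `C=C[C@@](C)(/C=C/c1ccc(Nc2ccccc2)cc1)CCC=C(C)C` is one of three related compounds tested in a functional assay on SEM cells (Homo sapiens) for cytotoxicity, with a stated time of 72 h; on this read-out lower numbers stand for an effect already at smaller amounts and higher numbers for an effect only at larger amounts of compound. In this assay compound 1 gives only a limit of the assay, > 36600 nM. Compound 2 `C=C[C@@](C)(/C=C/c1ccc(Nc2ccc(Cl)c(F)c2)cc1)CCC=C(C)C` likewise gives only a limit, > 36600 nM. Compound 3 `C=C[C@@](C)(/C=C/c1ccc(Nc2ccc(Cl)c(Cl)c2)cc1)CCC=C(C)C` also gives only a limit, > 36600 nM. All three sit at the limit of > 36600 nM in this assay, at which 3 of the 3 values shown sit, so the steps a step that the two limits leave unreadable from compound 1 to compound 2, a step that the two limits leave unreadable from compound 1 to compound 3 and a step that the two limits leave unreadable from compound 2 to compound 3 are of unreadable size. Compound 4 `C=C[C@@](C)(/C=C/c1ccc(Nc2ccc(C(F)(F)F)cc2)cc1)CCC=C(C)C` differs from compound 1 by trifluoromethyl in place of hydrogen on an aromatic carbon. Within the data shown here, no measured step tells how such a change acts, and each change tried so far on this outer ring left the limit untouched. Compound 4 is therefore expected to give an estimated value of 50000 nM, between 15000 nM and 200000 nM. This expectation amounts to an estimated step that the limit leaves unreadable from compound 1 to compound 4.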

Compound 4, half-maximal effective concentration: > 36600 nM
Compound 4 was reported as a limit; the forecaster's own chance of this, stated with the estimate: 85%; the middle value does not contradict the limit.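

Compound 4 gives only a limit in this assay, > 36600 nM, so no step from compound 1 to it can be read: the limit of > 36600 nM in this assay, at which 4 of the 4 values shown sit.

The compounds shown leave open whether any change on the outer ring brings a measurable effect in this assay.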